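Swapping methoxymethyl for phenyl on the shared core

This account rests on a few compounds, and the source may have more. Where it says the series, first, only, none or still open, it means among the compounds named here.

Compound 1, `O/N=C(/Nc1cccc(F)c1)c1ccc2occc2c1`: 32700 nM
Compound 2, `COCc1cc2cc(/C(=N\O)Nc3cccc(F)c3)ccc2o1`: 7100 nM

Both compounds were tested in an assay on isolated protein for inhibition of Indoleamine 2,3-dioxygenase 1 (Homo sapiens), read by spectrophotometry; on this read-out lower numbers stand for stronger inhibition and higher numbers for weaker inhibition. Compound 1 gives 32700 nM, and compound 2 gives 7100 nM. Within the data shown here, compound 2 therefore holds the lowest of the two numbers, and the one step between them, a 4.6-fold lower number from compound 1 to compound 2 (0.66 log units; beyond the scatter), shows that placing a methoxymethyl group on the shared core strengthens inhibition modestly.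

Compound 3, `O/N=C(/Nc1cccc(F)c1)c1ccc2oc(-c3ccccc3)cc2c1`, has not yet been measured. It differs from compound 2 in one place: phenyl in place of methoxymethyl on an aromatic carbon. Among the measured compounds shown here, the only step that bears on this position is a 4.6-fold lower number from compound 1 to compound 2 (0.66 log units; beyond the scatter), which shows that occupying this carbon with a group is tolerated and helps. For the measured compounds named here, nothing measured so far tells how a phenyl ring, rather than a methoxymethyl chain, behaves there, so the expectation rests on that single step alone. On that basis compound 3 is expected to land close to compound 2, with a step of about a 1.4-fold lower number from compound 2 to compound 3 (0.15 log units; within the scatter) in this assay. The estimate for compound 3 is 5000 nM, within a range of 1000 nM to 25000 nM.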

Compound 3, half-maximal inhibitory concentration: 11000 nM
For compound 3 the middle estimate is 2.2-fold (0.34 log units) below the measured one; measured number inside the range.
By their numbers in this assay, from the lowest: compounds 2 and 3 (each within the scatter of the next); then compound 1.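

In this assay, replacing hydrogen with phenyl on this carbon, next to the ring oxygen, gives a 3.0-fold lower number from compound 1 to compound 3 (0.47 log units; beyond the scatter) and so stronger inhibition, which means the benefit first seen with methoxymethyl is not confined to that one group. The comparison of the two groups gives a 1.5-fold higher number from compound 2 to compound 3 (0.19 log units; within the scatter) and so does not separate them, even though one is an open chain containing an oxygen and the other is a six-membered aromatic ring of carbon only. This carbon therefore accepts two very different groups, and neither the ring nor the chain oxygen is needed for the gain over hydrogen. The data give no explanation of why either group strengthens inhibition.

The compounds shown leave open how an amine, a carboxylic acid or a longer chain would behave on this carbon, and whether a group as small as methyl would already give the same gain. They also leave open whether adding a substituent such as chlorine or methoxy to the phenyl ring would move the number beyond what these two groups reach.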